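Removing the Fluorine From Compound 1: What to Expect

This account rests on a few compounds, and the source may have more. Where it says the series, first, only, none or still open, it means among the compounds named here.

The three measured compounds were tested in a functional assay on HT-29 cells (Homo sapiens) for antiproliferative activity, read by MTT assay, with a stated time of 24 h; a higher number here means a weaker inhibitor, a lower number a stronger inhibitor:

compound 1 `COc1ccc(C(=O)/C=C/c2ccc(F)cc2)c2c1C=CC(C)(C)O2` — > 10000 nM, a limit of the assay and not a number
compound 2 `COc1ccc(C(=O)/C=C/c2ccc(N3CCCC3)cc2)c2c1C=CC(C)(C)O2` — 8360 nM
compound 3 `COc1ccc(C(=O)/C=C/c2ccc3ccccc3n2)c2c1C=CC(C)(C)O2` — 3790 nM

Compound 1 stands at the limit of the assay, so only a range is known for it (the limit of > 10000 nM in this assay, at which 1 of the 3 values shown sits). Compound 2 sits just below that limit and compound 3 gives the lowest of the three numbers.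

Compound 4 `COc1ccc(C(=O)/C=C/c2ccccc2)c2c1C=CC(C)(C)O2` differs from compound 1 in one place: hydrogen in place of fluoro on an aromatic carbon. Going by the values given here, the only measured step that touches the same aromatic carbon is the one from compound 1 to compound 2, an at least 1.1-fold lower number from compound 1 to compound 2 (0.07 log units; that floor lies within the scatter), which is a large group entering and is only a floor because compound 1 itself is a limit. Nothing measured here shows a fluoro being replaced by hydrogen, so no step beyond the scatter can be read for it from these data.

Compound 4 is therefore expected to stay near the limit where compound 1 stands, with an estimated step that the limit leaves unreadable from compound 1 to compound 4. The estimate for compound 4 in this assay is 12000 nM, with a range from 5000 nM to 30000 nM, and it is likely that only a limit is reported.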

Compound 4, half-maximal inhibitory concentration: > 10000 nM
Compound 4: a limit, no number; the forecaster's own chance of this, stated with the estimate: 65%; the middle value lies beyond the limit too.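

In this assay compound 4 gives > 10000 nM, a limit of the assay and not a number. Going by these compounds alone, the step for hydrogen in place of fluoro on this aromatic carbon therefore cannot be read, but the result does show something the earlier compounds did not: the 4-fluorophenyl and the phenyl compound now stand at the same limit, so neither gives a number that can be compared with the other: the limit of > 10000 nM in this assay, at which 2 of the 4 values shown sit. Against the pyrrolidin-1-yl group, the new compound yields only an at least 1.1-fold higher number from compound 2 to compound 4 (0.07 log units; that floor lies within the scatter), so no effect of that group on this carbon is established either.

The compounds shown leave open whether any group on this aromatic carbon can bring the number clearly inside the limit, since a hydroxyl, a carboxylic acid or a primary amine there would be a different kind of substituent from those present so far. They also leave open how far beyond the limit the fluoro and hydrogen compounds really lie, and whether the two differ at all.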